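Anilino variation at the amine of a shared quinazoline-like series

The source may report more compounds than this note shows. Statements on the series, on what has been measured and on what is new or still open speak of the compounds shown alone.

Measured so far:
- compound 1 `CCCCCCCCNc1nc(SCc2ccc(C(F)(F)F)cc2)nc2ccccc12`: 22300 nM
- compound 2 `FC(F)(F)c1ccc(CSc2nc(Nc3ccccc3Cl)c3ccccc3n2)cc1`: limit, see below
- compound 3 `Fc1ccc(Nc2nc(SCc3ccc(C(F)(F)F)cc3)nc3ccccc23)cc1`: 15000 nM

In a functional assay on MDA-MB-231 cells (Homo sapiens) for cytotoxicity, read by MTT assay, with a stated time of 72 h (on this read-out higher numbers stand for weaker inhibition and lower numbers for stronger inhibition), compound 1 gives 22300 nM. For compound 2 this assay reports only a limit, > 50000 nM. Compound 3 gives 15000 nM, the lower of the two numbers, with compound 1 within the scatter of it: a 1.5-fold lower number from compound 1 to compound 3 (0.17 log units; within the scatter). Compound 2 stands apart, an at least 3.3-fold lower number from compound 2 to compound 3 (0.52 log units; beyond the scatter), and the step of an at least 2.2-fold higher number from compound 1 to compound 2 (0.35 log units; beyond the scatter) runs the same way.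

Compound 4 `COc1ccc(Nc2nc(SCc3ccc(C(F)(F)F)cc3)nc3ccccc23)c(OC)c1` differs from compound 3 by 2,4-dimethoxyphenyl in place of 4-fluorophenyl on a nitrogen on an aromatic ring. Among the measured compounds shown here, the only steps that bear on it are the two aryl exchanges; the one involving compound 2 was beyond the scatter, the other not. A modest step towards weaker inhibition is expected, a 1.7-fold higher number from compound 3 to compound 4 (0.22 log units; within the scatter). Compound 4 is thus estimated at 25000 nM in this assay, between 10000 nM and 60000 nM.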

Compound 4, half-maximal inhibitory concentration: > 50000 nM
Compound 4 ended at the assay's limit (the forecaster's own chance of this, stated with the estimate: 30%); at least 2.0-fold (0.30 log units) between middle value and limit.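

Compound 4 sits at a limit of this assay, so its true value is not known. Exchanging the aryl group on this nitrogen now has a clear cost beyond 2-chlorophenyl: an at least 3.3-fold higher number from compound 3 to compound 4 (0.52 log units; beyond the scatter), and against the octyl compound, an at least 2.2-fold higher number from compound 1 to compound 4 (0.35 log units; beyond the scatter). The step between compound 2 and compound 4 cannot be read, since both values are limits: the limit of > 50000 nM in this assay, at which 2 of the 4 values shown sit.

Still open, on these data alone, is whether 2-methoxyphenyl or 4-methoxyphenyl alone would reach that limit. Also open, as far as these compounds go, is how a shorter butyl chain or a morpholine would compare on this nitrogen.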